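Three trimethoxyphenyl triazoles at the assay limit and a nitro analogue

A few compounds are considered here, and "the series" means these few. Any claim that something is new, unique, unknown or untested is made for them only; others in the source may bear on it.

Compound 1 `COc1cc(-c2ncnn2-c2cccc(N)c2)cc(OC)c1OC` — in a functional assay on K562 cells (Homo sapiens) for antiproliferative activity, read by MTT assay, with a stated time of 72 h (on this read-out lower numbers stand for stronger inhibition and higher numbers for weaker inhibition), compound 1 gives > 10000 nM, a limit of the assay and not a number.
Compound 2 `COc1cc(-c2ncnn2-c2ccccc2)cc(OC)c1OC` — in this assay compound 2 gives > 10000 nM, again only a limit.
Compound 3 `COc1cc(-c2ncnn2-c2ccc(Cl)c(Cl)c2)cc(OC)c1OC` — in this assay compound 3 gives > 10000 nM, also a limit.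

Compound 2 therefore stands at the same limit as the other two measured compounds, and the limit of > 10000 nM in this assay, at which 3 of the 3 values shown sit, sums up the whole picture. Going by the values given here, none of the measured steps can be read: a step that the two limits leave unreadable from compound 1 to compound 2, a step that the two limits leave unreadable from compound 1 to compound 3 and a step that the two limits leave unreadable from compound 2 to compound 3 all remain hidden by the two limits.

Compound 4 `COc1cc(-c2ncnn2-c2cccc([N+](=O)[O-])c2)cc(OC)c1OC` is the compound still to be measured. It differs from compound 2 in one place, (nitro in place of hydrogen on an aromatic carbon). No readable step bears on this change, since every measured pair sits at the limit on both sides. Among the compounds with values here, the expectation for this assay is therefore no step that can be distinguished from the scatter, with compound 4 most likely also reported at the limit. Compound 4 is estimated at 15000 nM, within 4000 nM to 60000 nM, an expected step that the limit leaves unreadable from compound 2 to compound 4.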

Compound 4, half-maximal inhibitory concentration: > 10000 nM
Compound 4 gave a limit, no number; the forecaster's own chance of this, stated with the estimate: 75%; the middle value is on the limit's open side.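

Compound 4 gives > 10000 nM in this assay, a limit and not a number. Its steps from compound 1 and from compound 2 therefore cannot be read. The compounds shown leave open whether any of these changes alters the activity, as all share one limit: the limit of > 10000 nM in this assay, at which 4 of the 4 values shown sit.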